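Swapping a Para Halogen for Trifluoromethoxy on the Phenoxy Arm

The source may hold more compounds than are shown below. What is called first, only, known or untested is meant among the compounds shown, and "the series" means these compounds.

Of the compounds shown here, three sharing one core have been tested in a functional assay on HepG2 cells (Homo sapiens) for antiproliferative activity, read by MTT assay, with a stated time of 72 h; on this read-out higher numbers stand for weaker inhibition and lower numbers for stronger inhibition. Compound 1 `Cc1nn(C)c(Oc2ccccc2F)c1/C=N\CCCCCCOc1cc2oc(=O)cc(C)c2cc1Cl` carries a 2-fluorophenyl on the ether oxygen; in this assay compound 1 reaches only the limit of > 25000 nM, which is a boundary of the measurement rather than a number (the limit of > 25000 nM in this assay, at which 1 of the 3 values shown sits). Compound 2 `Cc1nn(C)c(Oc2ccc(Cl)cc2)c1/C=N\CCCCCCOc1cc2oc(=O)cc(C)c2cc1Cl` carries 4-chlorophenyl instead and gives 2960 nM, a change of an at least 8.4-fold lower number from compound 1 to compound 2 (0.92 log units; beyond the scatter). Compound 3 `Cc1nn(C)c(Oc2ccc(Br)cc2)c1/C=N\CCCCCCOc1cc2oc(=O)cc(C)c2cc1Cl` carries 4-bromophenyl and gives 4630 nM, a change of an at least 5.3-fold lower number from compound 1 to compound 3 (0.73 log units; beyond the scatter). Between the two halogens the step is a 1.6-fold higher number from compound 2 to compound 3 (0.19 log units; within the scatter), so compound 3 holds the higher of the two numbers, yet its gap to compound 2 lies within the scatter.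

Compound 4 `Cc1nn(C)c(Oc2ccc(OC(F)(F)F)cc2)c1/C=N\CCCCCCOc1cc2oc(=O)cc(C)c2cc1Cl` is the next step: trifluoromethoxy in place of bromo on an aromatic carbon. Within the data shown here, the only step that closely resembles it, the bromo-for-chloro swap, stayed within the scatter, while both steps from compound 1 show that a group in this position can shift the number strongly. A step of a 1.0-fold lower number from compound 3 to compound 4 (0.01 log units; within the scatter) in this assay is therefore expected, with no firm direction. For compound 4 the estimated value is 4500 nM, between 1500 nM and 14000 nM.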

Compound 4, half-maximal inhibitory concentration: 8160 nM
The estimate for compound 4 lay 1.8-fold (0.26 log units) below the measured number, and the stated range covers the measured number.
By their numbers in this assay, from the lowest: compounds 2, 3 and 4 (each within the scatter of the next, the first and the last beyond it). At a limit, above all of these: compound 1.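

Swapping a single halogen atom for trifluoromethoxy, a group of more heavy atoms that adds a hydrogen-bond acceptor, gives in this assay a 1.8-fold higher number from compound 3 to compound 4 (0.25 log units; within the scatter), but a 2.8-fold higher number from compound 2 to compound 4 (0.44 log units; beyond the scatter), so this position can separate groups even though chloro and bromo stay within the scatter of each other. The change away from the 2-fluorophenyl still holds with the new group, at an at least 3.0-fold lower number from compound 1 to compound 4 (0.48 log units; beyond the scatter). Compound 1 gives a limit and not a number: the limit of > 25000 nM in this assay, at which 1 of the 4 values shown sits.

The compounds shown leave open what an amine, a carboxylic acid or a plain methoxy would do on this aromatic carbon. They also cannot separate the identity of a substituent from its place on the ring: compound 1 differs from the others in both.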